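Chain-end swap: carboxylic acid to methylsulfanyl group

A few compounds are considered here, and "the series" means these few. Any claim that something is new, unique, unknown or untested is made for them only; others in the source may bear on it.

Compound 1 `CC(=O)c1cc(CC2CO2)c(OCCCCC#N)cc1O` gives 62% in an assay on isolated protein for inhibition of leukotriene B4 receptor 1 (Homo sapiens), tested at 10 uM; on this read-out higher numbers stand for more inhibition at the one concentration tested (going by the name of the read-out) and lower numbers for less inhibition.
Compound 2 `CCc1cc(C(C)=O)c(O)cc1OCCCCCC(C)(C)C#N` gives 85% in this assay.
Compound 3 `CCc1cc(C(C)=O)c(O)cc1OCCCC(C)(C)C(=O)O` gives 89% in this assay.

Compound 3 holds the highest number of the three in this assay; compound 2 sits within the scatter of it, while compound 1 lies beyond the scatter below it. The unmeasured compound 4 `CCc1cc(C(C)=O)c(O)cc1OCCCCCCSC` differs from compound 3 in one place: 3-(methylsulfanyl)propyl in place of 1-carboxy-1-methylethyl on a saturated chain carbon, three bonds along the chain from an oxygen on an aromatic ring. Among the measured compounds shown here, the one measured step at the same place, a number 4 percentage points higher from compound 2 to compound 3 (within the scatter), was within the scatter, so exchanging the chain-end group there left the read-out nearly unchanged. Compound 1 and compound 2 differ in two places and allow no single-change reading. Compound 4 is therefore expected to stay close to compound 3, with a modest drop allowed: a number 13 percentage points lower from compound 3 to compound 4 (beyond the scatter). The estimate for compound 4 in this assay is 76%, within 55% to 92%.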

Compound 4, a percentage reported as inhibition, at one concentration (the size of the read-out at that concentration, not a potency): 71%
The estimate for compound 4 lay 5 percentage points above the measured number; measured number inside the range.
By their numbers in this assay, from the lowest: compounds 1 and 4 (each within the scatter of the next); then compounds 2 and 3 (each within the scatter of the next).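

At this position the chain end is not interchangeable: this assay shows a number 18 percentage points lower from compound 3 to compound 4 (beyond the scatter) and also a number 14 percentage points lower from compound 2 to compound 4 (beyond the scatter), whereas the earlier exchange there stayed within the scatter. The 3-(methylsulfanyl)propyl end, with no hydrogen-bond donor, therefore retains inhibition but falls short of both the carboxylic acid and the nitrile chain ends. Nothing shown here explains this drop. As far as these compounds go, it remains open whether a chain ending in an amine or a primary amide would stay with the carboxylic acid and nitrile ends or with the methylsulfanyl end.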